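The source may hold more compounds than are shown below. What is called first, only, known or untested is meant among the compounds shown, and "the series" means these compounds.

Compound 1, `Cc1ccc2[nH]c(C(=O)N[C@H]3CN(S(=O)(=O)c4ccccc4)C[C@@H]3C(=O)NCCN(C)C)cc2c1`, gives 16 uL/min in an ADME assay on cells (Hepatocyte, Rattus norvegicus) for metabolic stability; on this read-out lower numbers stand for slow clearance and higher numbers for fast clearance.
Compound 2, `Cc1ccc2[nH]c(C(=O)N[C@H]3CN(S(=O)(=O)c4cnccn4)C[C@@H]3C(=O)NCCN(C)C)cc2c1`, gives 12 uL/min.
Compound 3, `Cc1ccc2[nH]c(C(=O)N[C@H]3CN(S(=O)(=O)c4cn(C)nc4C)C[C@@H]3C(=O)NCCN(C)C)cc2c1`, gives 4 uL/min.

All three share the same core and differ only in the group attached to the sulfonyl sulfur. Compound 1 stands at the top end of these three numbers. Compound 2 lies within the scatter of compound 1 (a 1.3-fold lower number from compound 1 to compound 2 (0.12 log units; within the scatter)), so the two cannot be told apart, while compound 3 sits clearly below compound 1 (a 4.0-fold lower number from compound 1 to compound 3 (0.60 log units; beyond the scatter)) and clearly below compound 2 (a 3.0-fold lower number from compound 2 to compound 3 (0.48 log units; beyond the scatter)).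

Compound 4, `Cc1ccc2[nH]c(C(=O)N[C@H]3CN(S(=O)(=O)c4ccccc4)C[C@@H]3C(=O)N[C@H]3CCCN(C)C3)cc2c1`, has not yet been measured in this assay. It differs from compound 1 at a different place: 1-methylpiperidin-3-yl in place of 2-(dimethylamino)ethyl on an amide-type nitrogen. Every measured step changes the group on the sulfonyl sulfur and leaves the amide-type nitrogen untouched, so none of them bears directly on this change; the data hold nothing on what a change at that nitrogen does. Without such a guide, the plainest expectation for compound 4 is a number close to that of compound 1, with no step beyond the scatter in either direction, and the estimated step is no change at the digits printed from compound 1 to compound 4 (within the scatter). For compound 4 the estimate is 16 uL/min, with an expected range from 7 uL/min to 36 uL/min.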

Compound 4, intrinsic clearance in a liver preparation (reported as CLH), per the amount of preparation that the assay uses: 23 uL/min
For compound 4 the middle estimate is 1.4-fold (0.16 log units) below the measured one, within the range that was stated.
By their numbers in this assay, from the lowest: compound 3; then compounds 2, 1 and 4 (each within the scatter of the next).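

Among these compounds, this pair gives the first reading at the amide-type nitrogen. In this assay, putting 1-methylpiperidin-3-yl in place of the open 2-(dimethylamino)ethyl chain gives a 1.4-fold higher number from compound 1 to compound 4 (0.16 log units; within the scatter), so the two compounds cannot be told apart, even though the new group is larger and brings a ring and a defined stereocentre. In this single pair, then, the change at the nitrogen leaves the clearance number within the scatter, while the clearest shift among the compounds shown remains the change on the sulfonyl sulfur, a 4.0-fold lower number from compound 1 to compound 3 (0.60 log units; beyond the scatter). No available measurement accounts for this result.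

The compounds shown leave open whether the same exchange at the nitrogen would stay within the scatter with the 1,3-dimethyl-1H-pyrazol-4-yl group of compound 3 on the sulfonyl sulfur, and whether the opposite arrangement at the new stereocentre would read the same. They also leave open how this nitrogen would respond to a smaller 1-methylpyrrolidin-3-yl ring, a longer 3-(dimethylamino)propyl chain, or a chain ending in a carboxylic acid instead of an amine.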